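The source may report more compounds than this note shows. Statements on the series, on what has been measured and on what is new or still open speak of the compounds shown alone.

Measured compounds in this series:

compound 1: `COC(=O)c1ccc(NC2=CC(=O)c3ncncc3C2=O)cc1`, 2200 nM
compound 2: `O=C1C(Nc2ccc(CO)cc2)=CC(=O)c2ncncc21`, 3500 nM
compound 3: `COc1ccc(NC2=CC(=O)c3ncncc3C2=O)cc1`, 1900 nM

In a functional assay on MIA PaCa-2 cells (Homo sapiens) for cytotoxicity, read by MTT assay, with a stated time of 72 h (on this read-out lower numbers stand for stronger inhibition and higher numbers for weaker inhibition), compound 3 gives the lowest of the three numbers, but none of the gaps among the three is beyond the scatter: a 1.2-fold lower number from compound 1 to compound 3 (0.06 log units; within the scatter), a 1.8-fold lower number from compound 2 to compound 3 (0.27 log units; within the scatter), and a 1.6-fold higher number from compound 1 to compound 2 (0.20 log units; within the scatter). On the numbers shown, the three substituents are not distinguished.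

Compound 4, `CCOC(=O)c1ccc(NC2=CC(=O)c3ncncc3C2=O)cc1`, is the next member: ethoxycarbonyl in place of methoxy on an aromatic carbon. Among the measured compounds shown here, the step that bears on it is the one between compound 1 and compound 3, which runs the reverse way across the same pair of group types, methoxycarbonyl against methoxy, and was small: a 1.2-fold lower number from compound 1 to compound 3 (0.06 log units; within the scatter). For the measured compounds named here, no measured pair separates ethoxycarbonyl from methoxycarbonyl, so that part of the change has no precedent here and is taken as neutral. The expected step in this assay is therefore none beyond the scatter, leaning slightly toward a higher number, a 1.2-fold higher number from compound 3 to compound 4 (0.08 log units; within the scatter). For compound 4 the estimate is 2300 nM, with a range of 1100 nM to 4800 nM.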

Compound 4, half-maximal inhibitory concentration: 5500 nM
Compound 4: middle estimate off by 2.4-fold (0.38 log units), on the low side; measured number above the stated range.
By their numbers in this assay, from the lowest: compounds 3, 1, 2 and 4 (each within the scatter of the next, the first and the last beyond it).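

In this assay this position, an aromatic carbon para to a large group, now shows a step beyond the scatter: a 2.9-fold higher number from compound 3 to compound 4 (0.46 log units; beyond the scatter) with ethoxycarbonyl in place of methoxy. The ester itself is sensitive to a small change, as methyl in place of hydrogen on the saturated chain carbon bound to an oxygen next to a carbonyl group gives a 2.5-fold higher number from compound 1 to compound 4 (0.40 log units; beyond the scatter) as a modest step, although methoxycarbonyl and methoxy were not separated. Ethoxycarbonyl is not separated from hydroxymethyl, with a 1.6-fold higher number from compound 2 to compound 4 (0.20 log units; within the scatter) as the step between them.

Nothing in hand gives a reason for the shift with the ethyl ester. As far as these compounds go, whether a longer chain such as propoxycarbonyl moves the number further remains open, as does the standing of a carboxylic acid or an amine at this position.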